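The source may hold more compounds than are shown below. What is called first, only, known or untested is meant among the compounds shown, and "the series" means these compounds.

Compound 2 `COC(C)(C)CC1n2cncc2CN([C@@H](C)c2ccc(Cl)cc2)S1(=O)=O` gives the lowest of the three numbers recorded in an assay on cells for inhibition of cytochrome P450 11B2, mitochondrial (Homo sapiens) (on this read-out lower numbers stand for stronger inhibition and higher numbers for weaker inhibition), at 0.9 nM. Compound 1 `CC(C)CC1n2cncc2CN(Cc2ccc(F)cc2)S1(=O)=O` gives 2.5 nM in this assay, and compound 3 `CC(C)CC1n2cncc2CN(CC2CC2)S1(=O)=O` gives 758 nM. Going by the values given here, the only measured step, a 300-fold higher number from compound 1 to compound 3 (2.48 log units; beyond the scatter), concerns the group on the sulfonamide nitrogen and not the side chain altered here. Compound 4 `CC(C)OCC1n2cncc2CN([C@@H](C)c2ccc(Cl)cc2)S1(=O)=O` differs from compound 2 by isopropoxy in place of 1-methoxy-1-methylethyl on a saturated chain carbon bound to a saturated ring carbon. Among the compounds with values here, no measured step tests a change at this place, so the data give no direction for it; a change that keeps the chain and its single acceptor is expected to produce no step beyond the scatter, a 1.7-fold higher number from compound 2 to compound 4 (0.22 log units; within the scatter). Compound 4 is therefore estimated to give 1.5 nM in this assay, between 0.5 nM and 5 nM.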

Compound 4, half-maximal inhibitory concentration: 0.8 nM
The estimate for compound 4 lay 1.9-fold (0.27 log units) above the measured number, within the range that was stated.
By their numbers in this assay, from the lowest: compounds 4 and 2 (each within the scatter of the next); then compound 1; then compound 3.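

In this assay the first change tested at this place, isopropoxy in place of 1-methoxy-1-methylethyl on a saturated chain carbon bound to a saturated ring carbon, gives a 1.1-fold lower number from compound 2 to compound 4 (0.05 log units; within the scatter) and so leaves the number within the scatter. The step thus shows that these two side chains, each with one hydrogen-bond acceptor, can be exchanged without a measurable change here. Nothing available explains why they read alike. Going by these compounds, whether an amine or a carboxylic acid on this chain would do the same remains open. So does whether this exchange would read alike with another group on the sulfonamide nitrogen.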